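The source may report more compounds than this note shows. Statements on the series, on what has been measured and on what is new or still open speak of the compounds shown alone.

Working notes on a set of bis(aziridinyl)quinone-type analogues sharing one core, assessed in a functional assay on L1210 cells (Mus musculus), with a stated time of 1 days; a lower number here means a less potent compound, a higher number a more potent compound, by a factor of ten per unit of this negative logarithm. Compound 1 `CN(C)C(=O)OCCC1=C(N2CC2)C(=O)C(CCOC(=O)N(C)C)=C(N2CC2)C1=O` gives 4.62. Compound 2 `CC(C)C1=C(N2CC2)C(=O)C(C(C)C)=C(N2CC2)C1=O` gives 4.14, and compound 3 `CC1=C(N2CC2)C(=O)C(COc2ccccc2)=C(N2CC2)C1=O` gives 3.89. On these three numbers compound 2 stands second highest: its nearest neighbour is compound 3, which lies within the scatter, and its furthest is compound 1, which lies higher by a margin beyond the scatter. For the measured compounds named here, no pair among the three differs in a single place, so no measured single-point step is available.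

Compound 4 `CC1=C(N2CC2)C(=O)C(C(C)C)=C(N2CC2)C1=O` is not yet measured. It differs from compound 2 in one place: methyl in place of isopropyl on a double-bonded ring carbon. Going by the values given here, nothing among the measured compounds isolates this exchange, and compound 3, which also carries a methyl on its core, sits within the scatter of compound 2. On that basis a step of no more than the usual scatter is expected, with no clear direction, and the estimated step is a number 0.04 log units lower from compound 2 to compound 4 (within the scatter). Compound 4 is therefore expected at 4.1 in this assay, with a range from 3.6 to 4.6.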

Compound 4, logarithm of the reciprocal of the active concentration, log(1/C): 4.69
For compound 4 the middle estimate is 0.59 log units below the measured one; the whole stated range lies below it.
By their numbers in this assay, from the lowest: compounds 3 and 2 (each within the scatter of the next); then compounds 1 and 4 (each within the scatter of the next).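

For the compounds shown here, the exchange of isopropyl for methyl on a double-bonded ring carbon gives in this assay the step of a number 0.55 log units higher from compound 2 to compound 4 (beyond the scatter) and is the first single-place change that can be read. Going by these compounds alone, it shows that this position is not indifferent to the group it carries, which the earlier compounds, differing in more than one place, could not show. The other isopropyl, three ring bonds away, remains in compound 4, so the step belongs to this one exchange, and no measurement at hand accounts for its size.

On these data alone, with only isopropyl and methyl compared at this carbon, it stays open whether hydrogen, ethyl or an amine there would extend or reverse the step. Also open, as far as these compounds go, is whether a second methyl in place of the remaining isopropyl would give a step of similar size.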